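Azole thioether to benzimidazolyl ether at the ketone methylene

The source may hold more compounds than are shown below. What is called first, only, known or untested is meant among the compounds shown, and "the series" means these compounds.

Compound 3 `CC(C)[C@H](NC(=O)COc1cccc2ccccc12)C(=O)N[C@@H](CC(=O)O)C(=O)CSc1nc[nH]n1` is read in a functional assay on Jurkat cells (Homo sapiens) for inhibition; a higher number here means a weaker inhibitor, a lower number a stronger inhibitor. Here compound 3 reaches only > 200000 nM, a limit of the assay and not a number. Compound 2 `CC(C)[C@H](NC(=O)COc1cccc2ccccc12)C(=O)N[C@@H](CC(=O)O)C(=O)CSc1nccn1C` likewise stops at the limit > 200000 nM. Within the data shown here, compound 1 `COC(=O)c1cc(OCC(=O)[C@H](CC(=O)O)NC(=O)[C@@H](NC(=O)COc2cccc3ccccc23)C(C)C)no1`, the one oxygen-linked analogue so far, gives 71000 nM. The steps of an at least 2.8-fold higher number from compound 1 to compound 2 (0.44 log units; beyond the scatter) and an at least 2.8-fold higher number from compound 1 to compound 3 (0.44 log units; beyond the scatter) show both azole thioethers falling behind the ether of compound 1. The step that the two limits leave unreadable from compound 2 to compound 3 cannot be sized; the limit of > 200000 nM in this assay, at which 2 of the 3 values shown sit, holds both of its compounds.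

Compound 4 `CC(C)[C@H](NC(=O)COc1cccc2ccccc12)C(=O)N[C@@H](CC(=O)O)C(=O)COc1nc2ccccc2[nH]1` carries (1H-benzimidazol-2-yl)oxy in place of (1H-1,2,4-triazol-3-yl)sulfanyl on a saturated chain carbon bound to a carbonyl carbon. On these data alone, this returns to an oxygen link as in compound 1, so the step of an at least 2.0-fold lower number from compound 3 to compound 4 (0.30 log units; that floor lies within the scatter) is expected to run toward lower numbers, though the benzimidazole itself is untested. Compound 4 is therefore estimated at 100000 nM, within 30000 nM to 250000 nM, with a fair chance that only the limit is reported again.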

Compound 4, half-maximal inhibitory concentration: > 200000 nM
Compound 4 ended at the assay's limit; the forecaster's own chance of this, stated with the estimate: 40%; middle value at least 2.0-fold (0.30 log units) from the limit.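

In this assay compound 4 stops at > 200000 nM, a limit of the assay and not a number. With the oxygen link kept, replacing 5-(methoxycarbonyl)-1,2-oxazol-3-yl with 1H-benzimidazol-2-yl gives an at least 2.8-fold higher number from compound 1 to compound 4 (0.44 log units; beyond the scatter), so an oxygen link alone does not secure the measurable inhibition of compound 1. The steps from compound 2 and compound 3 to compound 4 cannot be read, and the series now sits mostly at one ceiling: the limit of > 200000 nM in this assay, at which 3 of the 4 values shown sit.

Whether oxygen or sulfur matters with the same ring stays open, since no shown pair isolates the link. Also open, on these data alone, is how a carboxylic acid in place of the methoxycarbonyl of compound 1 would read.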